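The compounds below may be only part of what the source reports. "The series", "measured", "known", "first", "only" and "open" are said of these compounds alone.

Measured so far:
Compound 1 `Cc1ccc(S(=O)(=O)N[C@@H](CC(=O)NC(C)(C)C)C(=O)NCCNC(=O)c2cccc(O)c2)cc1` — in an ADME assay on HepG2 cells (Homo sapiens) for cytotoxicity (on this read-out lower numbers stand for an effect already at smaller amounts and higher numbers for an effect only at larger amounts of compound), compound 1 gives > 11000 nM, a limit of the assay.
Compound 2 `Cc1ccc(S(=O)(=O)N[C@@H](CC(=O)NC(C)(C)C)C(=O)NCCNC(=O)c2ccccc2Cl)cc1` — compound 2 gives > 11000 nM, likewise a limit.
Compound 3 `Cc1ccc(S(=O)(=O)N[C@@H](CC(=O)NC(C)(C)C)C(=O)NCCNC(=O)c2cccc(C#N)c2)cc1` — compound 3 gives > 11000 nM, again a limit.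

Among the compounds with values here, compound 2 therefore stands at the limit of > 11000 nM in this assay, at which 3 of the 3 values shown sit; no compound in the set has a readable number. The steps a step that the two limits leave unreadable from compound 1 to compound 2 and a step that the two limits leave unreadable from compound 2 to compound 3 are both unreadable, as is a step that the two limits leave unreadable from compound 1 to compound 3.

Compound 4 `Cc1ccc(S(=O)(=O)N[C@@H](CC(=O)NC(C)(C)C)C(=O)NCCNS(=O)(=O)c2ccccc2)cc1` differs from compound 2 by phenylsulfonyl in place of (2-chlorophenyl)carbonyl on an amine nitrogen. Within the data shown here, no measured step carries this change, and the measured changes at the same amine nitrogen gave nothing readable, so no direction can be taken from them. Compound 4 is expected to stay at the limit, with a step that the limit leaves unreadable from compound 2 to compound 4 as the expected step, none beyond the scatter. The estimate for compound 4 is 20000 nM, range 8000 nM to 60000 nM.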

Compound 4, half-maximal effective concentration: > 11000 nM
Compound 4 was reported as a limit (the forecaster's own chance of this, stated with the estimate: 85%); the middle value does not contradict the limit.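

Compound 4 joins compound 1, compound 2 and compound 3 at the limit, so no step among these four compounds can be read in this assay: the limit of > 11000 nM in this assay, at which 4 of the 4 values shown sit.

As far as these compounds go, whether any change on the amine nitrogen shifts the read-out at all stays open.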